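Series notes: from compound 1 to compound 4

A few compounds are considered here, and "the series" means these few. Any claim that something is new, unique, unknown or untested is made for them only; others in the source may bear on it.

Compound 1 `Cc1cc(Nc2ccn(Cc3cccc4ccccc34)n2)n2nc(SCc3ccc(Br)cc3)nc2n1` gives 5660 nM in a functional assay on PC-9 cells (Homo sapiens) for inhibition, read by MTT assay, with a stated time of 72 h; on this read-out lower numbers stand for stronger inhibition and higher numbers for weaker inhibition. Among the three measured compounds it stands second highest, with compound 2 `Cc1cc(Nc2cc(-c3ccccc3)[nH]n2)n2nc(SCc3c(Cl)cccc3Cl)nc2n1` nearest at 5180 nM and compound 3 `Cc1cc(Nc2cc(-c3ccccc3)[nH]n2)n2nc(SCc3ccc(F)cc3)nc2n1` furthest at 8110 nM; both gaps lie within the scatter. Within the data shown here, the one step between compounds differing in a single place, a 1.6-fold higher number from compound 2 to compound 3 (0.19 log units; within the scatter), sits on a saturated chain carbon bound to a sulfur and is itself within the scatter. Compound 4 `Cc1cc(Nc2ccn(Cc3nc(C)c4ccccc4n3)n2)n2nc(SCc3ccc(Br)cc3)nc2n1` differs from compound 1 by 4-methylquinazolin-2-yl in place of naphthalen-1-yl on a saturated chain carbon bound to an aromatic nitrogen. Among the measured compounds shown here, no measured step touches this place, so nothing beyond the scatter can be expected in this assay. Compound 4 is therefore estimated at 5500 nM (range 1500 nM to 20000 nM), which would mean an expected 1.0-fold lower number from compound 1 to compound 4 (0.01 log units; within the scatter).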

Compound 4, half-maximal inhibitory concentration: 5450 nM
For compound 4 the middle estimate is 1.0-fold (0.00 log units) above the measured one; measured number inside the range.
By their numbers in this assay, from the lowest: compounds 2, 4, 1 and 3 (each within the scatter of the next).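

At the place on a saturated chain carbon bound to an aromatic nitrogen, the step reads a 1.0-fold lower number from compound 1 to compound 4 (0.02 log units; within the scatter) in this assay. Among these compounds, this is the first reading at this place, and it does not separate (naphthalen-1-yl)methyl from (4-methylquinazolin-2-yl)methyl, although the entering group counts 2 hydrogen-bond acceptors and the leaving group 0. No supporting data bear on this result.

On these data alone, whether a morpholine or a carboxylic acid in place of these aromatic rings would move the number beyond the scatter stays open. So does whether this exchange reads the same with another group on the sulfur.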